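A few compounds are considered here, and "the series" means these few. Any claim that something is new, unique, unknown or untested is made for them only; others in the source may bear on it.

Working notes on the series in a toxicity assay on J774.A1 cells (Mus musculus) for cytotoxicity, read by SYBR Green assay, with a stated time of 1 h; on this read-out higher numbers stand for an effect only at larger amounts of compound and lower numbers for an effect already at smaller amounts. Compound 1 (`CN(C)c1ccc2cc(-c3ccsc3)c(N)nc2c1`) gives "not determined" (no result reported). For the measured compounds named here, compound 2 (`CN(C)c1ccc2cc(-c3ccccn3)c(N)nc2c1`) gives 2200 nM, the only number so far, so its standing cannot yet be ranked against another compound. Compound 3 (`CN(C)c1ccc2cc(-c3ncccc3F)c(N)nc2c1`) carries one change from compound 2: fluoro in place of hydrogen on an aromatic carbon, taking pyridin-2-yl to 3-fluoropyridin-2-yl. Going by the values given here, no measured pair shows the size of such a step, so no shift beyond the usual scatter is expected, in either direction. The expected step is a 1.1-fold higher number from compound 2 to compound 3 (0.04 log units; within the scatter). For compound 3 the estimated value is 2400 nM, with an expected range of 1000 nM to 6000 nM.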

Compound 3, half-maximal effective concentration: 16000 nM
Compound 3: the middle estimate sits 6.7-fold (0.82 log units) below what was measured; measured number outside the range, above it.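

In this assay, fluoro in place of hydrogen on this aromatic carbon, two atoms from the ring nitrogen, gives a 7.3-fold higher number from compound 2 to compound 3 (0.86 log units; beyond the scatter) and so moves the read-out beyond the scatter, toward an effect only at larger amounts of compound. For the compounds shown here, this is the first measured step, and it shows that a change of one heavy atom at this position can be enough to shift the number. Nothing at hand accounts for the shift.

Whether the shift belongs to fluoro itself remains open, since no other group at this position is shown. Chloro, methoxy or an amine here could separate that question, and the same fluoro elsewhere on the ring could show whether the position matters.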